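The source may hold more compounds than are shown below. What is called first, only, known or untested is meant among the compounds shown, and "the series" means these compounds.

Measured in an ADME assay on Huh-7 cells (Homo sapiens) for cytotoxicity; a lower number here means that less compound is tolerated, a higher number that more compound is tolerated:
compound 1 `CN1CCN(CCNCc2cn(-c3ccc(F)cc3F)nc2Cc2ccccc2)CC1` — a limit of the assay, > 20000 nM
compound 2 `CN1CCN(CCNCc2cn(-c3ccc(F)cc3F)nc2-c2ccc(OC(F)(F)F)cc2)CC1` — 18000 nM
compound 3 `CN1CCN(CCNCc2cn(-c3ccc(F)cc3F)nc2-c2ccccc2)CC1` — a limit of the assay, > 20000 nM

Compound 3 thus stands at the limit of this assay, and compound 1 sits at the same limit (the limit of > 20000 nM in this assay, at which 2 of the 3 values shown sit). Only compound 2 returns a number, and that number lies close to the limit itself. The measured steps say little: an at least 1.1-fold higher number from compound 2 to compound 3 (0.04 log units; that floor lies within the scatter) and an at least 1.1-fold lower number from compound 1 to compound 2 (0.04 log units; that floor lies within the scatter) are floors that lie within the scatter, and a step that the two limits leave unreadable from compound 1 to compound 3 cannot be read at all. Nothing among the three shown compounds is separated from another by more than the scatter.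

Compound 4 `Cc1cccc(-c2nn(-c3ccc(F)cc3F)cc2CNCCN2CCN(C)CC2)c1` differs from compound 3 by methyl in place of hydrogen on an aromatic carbon. Going by the values given here, no measured step swaps hydrogen for methyl; the nearest in kind, an at least 1.1-fold higher number from compound 2 to compound 3 (0.04 log units; that floor lies within the scatter), exchanges hydrogen for trifluoromethoxy and is itself unreadable beyond its floor. Given that the three shown compounds all cluster at or near the limit of this assay, a small methyl is expected to move the number by nothing that exceeds the scatter, and compound 4 is expected to come back at the limit once more. Compound 4 is therefore estimated at 20000 nM, within 9000 nM to 45000 nM, a step of a number no higher from compound 3 to compound 4 (the limit leaves the size open) that is expected to remain within the scatter.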

Compound 4, half-maximal cytotoxic concentration: > 20000 nM
Compound 4 was reported as a limit; the forecaster's own chance of this, stated with the estimate: 65%; the middle value lies on the limit itself.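

With phenyl changed to 3-methylphenyl, the position now carries a small added methyl, and in this assay compound 4 still returns only a limit, > 20000 nM. This adds a third compound at the ceiling of the measurement, so a plain phenyl, a benzyl and now a 3-methylphenyl all end in the same place, with compound 2 the only one to return a number: the limit of > 20000 nM in this assay, at which 3 of the 4 values shown sit.
Going by these compounds alone, the one step that can be read is an at least 1.1-fold higher number from compound 2 to compound 4 (0.04 log units; that floor lies within the scatter), and the steps from compound 3 and from compound 1 to compound 4 cannot be read, with a limit at both ends.

From the compounds shown here alone, how far compound 1, compound 3 and compound 4 lie beyond the limit stays open, so no order among them can be given. Also open, going by these compounds, is whether a carboxylic acid or an amine in place of the methyl would give a number clearly under the limit.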